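The compounds below may be only part of what the source reports. "The series", "measured", "known", "first", "only" and "open" are said of these compounds alone.

Working notes on the series in an assay on isolated protein for inhibition of protein arginine N-methyltransferase 6 (Homo sapiens); a higher number here means a weaker inhibitor, a lower number a stronger inhibitor.

Compound 1 `CN(CCN)Cc1ccccc1` gives 2500 nM in this assay. Compound 2 `NCCN1CCC(c2nnc(Cn3ccnc3)n2C2CC2)CC1` is reported in this assay as "not active" (no number reported), without a number. Compound 3 `NCC(=O)NCc1cccnc1Oc1ccc(F)cc1F` is likewise reported in this assay as "not active" (no number reported), again with no number attached, so compound 3 stands outside the measurable range of the set and cannot be ranked against compound 1 beyond that.

Compound 4 `NC1(C(=O)NCc2cccnc2Oc2ccc(F)cc2F)CC1` differs from compound 3 in one place: 1-aminocyclopropyl in place of aminomethyl on a carbonyl carbon. Among the compounds with values here, no pair of measured compounds shows this change, so no measured step can be drawn on. Compound 3 offers no number from which a direction could be read, and the change is small in what it adds. The expectation for this assay is therefore no step beyond the scatter from where compound 3 stands, most likely another entry without a number.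

Compound 4 is estimated at 50000 nM in this assay, within a range from 10000 nM to 200000 nM.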

Compound 4, half-maximal inhibitory concentration: "not active" (no number reported)
Compound 4 has no reported number here; there is nothing to compare the estimate with.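

In this assay compound 3 and compound 4 are both reported as not active, without a number, so no step can be read between them. As far as these compounds go, whether aminomethyl or 1-aminocyclopropyl on this carbonyl carbon makes any difference stays open. No further data bear on this result.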